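Swapping phenyl for cyclopropyl on an alkyne arm

The source may hold more compounds than are shown below. What is called first, only, known or untested is meant among the compounds shown, and "the series" means these compounds.

Of the compounds shown here, two have so far been tested in a functional assay on K562 cells (Homo sapiens) for cytotoxicity, read by thymidine incorporation, with a stated time of 48 h; on this read-out lower numbers stand for stronger inhibition and higher numbers for weaker inhibition. Compound 1 `O=c1nc2c(cn1Cc1ccccc1)ncn2Cc1ccccc1` gives only a limit there: in this assay compound 1 reads > 10 ug/mL, which is a limit of the measurement and not a number, and the limit of > 10 ug/mL in this assay, at which 1 of the 2 values shown sits, is where compound 1 sits. Compound 2 `O=C1Nc2c(ncn2Cc2ccccc2)C(C#Cc2ccccc2)N1Cc1ccccc1` carries a 2-phenylethynyl arm on the shared core and does give a number: in this assay compound 2 shows 0.8 ug/mL. For the measured compounds named here, that is the only measured number in the set, the other entry being the limit just described, so compound 2 cannot be placed above or below any other compound.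

Compound 3 `O=C1Nc2c(ncn2Cc2ccccc2)C(C#CC2CC2)N1Cc1ccccc1` has not been measured. It differs from compound 2 in one place: cyclopropyl in place of phenyl on a triple-bonded carbon. Going by the values given here, no measured pair shows what this change does here. A modest weakening is expected for compound 3, a 2.3-fold higher number from compound 2 to compound 3 (0.35 log units; beyond the scatter), a step somewhat beyond the scatter but not large. For compound 3 the estimated value in this assay is 1.8 ug/mL, with a range from 0.6 ug/mL to 6 ug/mL.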

Compound 3, half-maximal inhibitory concentration: 1.3 ug/mL
Estimate against measurement, compound 3: 1.4-fold (0.14 log units) above, and the stated range covers the measured number.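

In this assay, putting cyclopropyl in place of phenyl on a triple-bonded carbon gives a 1.6-fold higher number from compound 2 to compound 3 (0.21 log units; within the scatter), so on this read-out compound 2 and compound 3 cannot be told apart. For the compounds shown here, this is the first pair in the set that differs in one place, and it shows that, at this one position on the shared core, a one-ring group of 6 heavy atoms and aromatic character can be exchanged for a non-aromatic three-membered ring of 3 heavy atoms with no step beyond the usual scatter of repeated measurements. One pair is all this rests on, and nothing measured here explains why the read-out holds steady across the change.

The compounds shown leave open whether any ring is needed at the end of the arm, which a plain methyl group, a longer butyl chain or a chain ending in an amine on the same triple-bonded carbon would help to answer. Going by these compounds, whether the triple bond itself matters also stays open, and only a pair in which that bond alone changes could settle it.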